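A few compounds are considered here, and "the series" means these few. Any claim that something is new, unique, unknown or untested is made for them only; others in the source may bear on it.

Of the compounds shown here, three sharing one core have been measured in a physicochemical assay for lipophilicity, in phosphate buffer, measured as octanol-water partition, with a stated time of 24 h; on this read-out higher numbers stand for higher lipophilicity and lower numbers for lower lipophilicity. Compound 1 `S=C(N/N=C/c1ccc(Oc2ccc3ccccc3c2)cc1)Nc1ccc(Br)cc1` gives 6.93 in this assay. Compound 3 `Fc1ccc(NC(=S)N/N=C/c2ccc(Oc3ccc4ccccc4c3)cc2)cc1` gives 6.2 in this assay, and compound 2 `Fc1ccc(NC(=S)N/N=C/c2ccc(Oc3ccc(Br)cc3)cc2)cc1` gives 5.88 in this assay, the lowest of the three, with both of its gaps to the others lying beyond the scatter.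

Compound 1 differs from compound 3 in one place, (bromo in place of fluoro on an aromatic carbon), and this change brought a number 0.73 log units higher from compound 3 to compound 1 (beyond the scatter). Compound 2 and compound 3 differ in their cores, (4-bromophenyl in place of naphthalen-2-yl on an oxygen on an aromatic ring), and that difference accounts for a number 0.32 log units higher from compound 2 to compound 3 (beyond the scatter).

A fourth compound, compound 4 `S=C(N/N=C/c1ccc(Oc2ccc(Br)cc2)cc1)Nc1ccc(Br)cc1`, has not yet been measured in this assay. It differs from compound 2 in one place, (bromo in place of fluoro on an aromatic carbon). The surroundings of that place read the same, word for word, as those of the change from compound 3 to compound 1, so the two changes are the same change made on two cores; among the four compounds it occurs twice in all.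

For compound 4 the expected step is a number 0.72 log units higher from compound 2 to compound 4 (beyond the scatter), which rests on the size of a number 0.73 log units higher from compound 3 to compound 1 (beyond the scatter) seen between the two measured compounds. Compound 4 is therefore expected to come out near 6.6, with a likely range from 6.2 to 7.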

Compound 4, partition coefficient: 6.53
For compound 4 the middle estimate is 0.07 log units above the measured one; the range from low to high includes it.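

In this assay, bromo in place of fluoro on an aromatic carbon gave a number 0.65 log units higher from compound 2 to compound 4 (beyond the scatter) on the core carrying 4-bromophenyl, and the same change gave a number 0.73 log units higher from compound 3 to compound 1 (beyond the scatter) on the core carrying naphthalen-2-yl, so the change carried over between these two cores in direction, with both steps beyond the scatter. The other new step, 4-bromophenyl in place of naphthalen-2-yl with bromo on the far ring, gave a number 0.40 log units lower from compound 1 to compound 4 (beyond the scatter), which agrees in direction with a number 0.32 log units higher from compound 2 to compound 3 (beyond the scatter), where the same two groups were exchanged the opposite way with fluoro on that ring. This rests on only two cores and one pair of groups, so it does not show that the step would carry to any further core, and nothing shown here bears on why the step takes the size it does.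

The compounds shown leave open whether the number would move the same way if an amine or a carboxylic acid stood on that aromatic carbon in place of bromo or fluoro. They also leave open whether the step would keep its direction if a longer chain stood on the oxygen in place of 4-bromophenyl or naphthalen-2-yl.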